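A few compounds are considered here, and "the series" means these few. Any claim that something is new, unique, unknown or untested is made for them only; others in the source may bear on it.

Working notes on the series. Going by the values given here, compound 1 `Cc1ccc(-c2ccccc2OC(C)C2=NCCN2)cc1` sits lowest of the two numbers measured so far: in an assay on CHO cells for displacement of a labelled ligand from Alpha-2C adrenergic receptor (Homo sapiens) (on this read-out lower numbers stand for stronger inhibition and higher numbers for weaker inhibition), compound 1 gives 251 nM. Compound 2 `CC(Nc1ccccc1-c1ccccc1)C1=NCCN1` gives 708 nM in this assay, a higher number that lies beyond the scatter of the method. Compound 3 `Cc1cccc(-c2ccccc2OC(C)C2=NCCN2)c1` remains to be measured in this assay; it is built from the same atoms as compound 1, joined differently: 3-methylphenyl in place of 4-methylphenyl on an aromatic carbon. Among the compounds with values here, no pair of measured compounds shares this kind of change, so nothing in the numbers at hand sets its size or direction. A methyl moved round the outer ring is a modest rearrangement, and the expectation is a step no larger than the scatter, in either direction. Compound 3 is therefore estimated at 300 nM in this assay, with a range from 120 nM to 750 nM, which corresponds to an expected step of a 1.2-fold higher number from compound 1 to compound 3 (0.08 log units; within the scatter).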

Compound 3, inhibition constant: 245 nM
For compound 3 the middle estimate is 1.2-fold (0.09 log units) above the measured one, and the stated range covers the measured number.
By their numbers in this assay, from the lowest: compounds 3 and 1 (each within the scatter of the next); then compound 2.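

Going by these compounds alone, the step of a 1.0-fold lower number from compound 1 to compound 3 (0.01 log units; within the scatter) in this assay is the first one read, and it lies within the scatter. On the outer ring, on an aromatic carbon of a six-membered aromatic ring of carbon only, 3-methylphenyl and 4-methylphenyl therefore cannot be told apart on this read-out, so the place of the methyl sets no order between these two compounds. No available evidence explains why the two compounds read alike.

This single pair says nothing about groups other than methyl on the outer ring, such as methoxy, a carboxylic acid or an amine. It also leaves open whether the same move of the methyl would read alike on the unsubstituted outer ring of compound 2, where the link to the shared core differs.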